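Shortening the Alkoxy Chain on a Chloroquinoline Core

This account rests on a few compounds, and the source may have more. Where it says the series, first, only, none or still open, it means among the compounds named here.

Measured compounds in a functional assay on RKO cells (Homo sapiens) for cytotoxicity, read by MTT assay, with a stated time of 48 h; a lower number here means a stronger inhibitor, a higher number a weaker inhibitor:
Compound 1 `CCCCCCOc1ccc2c(Cl)ccnc2c1` gives 2720 nM.
Compound 2 `CCCCCCOc1ccc2c(NCCN(C)C)ccnc2c1` gives 1120 nM.
Compound 3 `Fc1ccc(COc2ccc3c(Cl)ccnc3c2)cc1` gives 1980 nM.

Among these three, compound 1 has the highest number, so it is the weakest inhibitor shown; compound 3 sits within the scatter of it, while compound 2 lies beyond it, with a 2.4-fold lower number from compound 1 to compound 2 (0.39 log units; beyond the scatter), where the change is a (2-(dimethylamino)ethyl)amino in place of chloro on an aromatic carbon.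

Compound 4 `CCCCOc1ccc2c(Cl)ccnc2c1` differs from compound 1 only in the side chain: hydrogen in place of ethyl on a saturated chain carbon, four bonds along the chain from an oxygen on an aromatic ring. The same difference can also be read as butyl to ethyl.

Among the compounds with values here, no measured pair shows a change of this kind; the only step beyond the scatter concerns the chloro group, which compound 4 keeps unchanged. Compound 3, which carries a different chain on the same oxygen, stays within the scatter of compound 1. So no step beyond the scatter is expected in this assay for compound 4, and the expected step of a 1.1-fold higher number from compound 1 to compound 4 (0.04 log units; within the scatter) is small.

Compound 4 is therefore estimated at 3000 nM, with a range from 1500 nM to 6000 nM.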

Compound 4, half-maximal inhibitory concentration: 3050 nM
Compound 4: middle estimate off by 1.0-fold (0.01 log units), on the low side, within the range that was stated.
By their numbers in this assay, from the lowest: compounds 2, 3, 1 and 4 (each within the scatter of the next, the first and the last beyond it).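

In this assay, within the data shown here, this pair gives the first direct reading of the chain on the oxygen: putting hydrogen in place of ethyl, four bonds along the chain from an oxygen on an aromatic ring, gives a 1.1-fold higher number from compound 1 to compound 4 (0.05 log units; within the scatter), with the chloro group and the rest of the core unchanged. Removing this ethyl therefore does not separate the two compounds in this assay, though a single pair cannot set a rule for the chain as a whole. No measurement shown here accounts for this result.

This one pair leaves open whether a much shorter chain, such as methyl, or a longer chain, such as octyl, on the same oxygen would also stay within the scatter. Also open, on these data alone, is whether an amine or a carboxylic acid at the chain end would move the number, and whether shortening the chain has the same small effect when the (2-(dimethylamino)ethyl)amino group of compound 2 replaces chloro.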